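Swapping an Aryl Amide Tail for a Thiol Ester Tail

The compounds below may be only part of what the source reports. "The series", "measured", "known", "first", "only" and "open" are said of these compounds alone.

Of the compounds shown here, three sharing one core have been tested in a functional assay on CLL cells (Homo sapiens) for cytotoxicity, read by MTT assay, with a stated time of 48 h; a lower number here means that less compound is needed, a higher number that more compound is needed for the effect. Compound 1 `C=C(CC)C(=O)c1ccc(OCC(=O)Nc2ccc(C(N)=O)cc2)c(Cl)c1Cl` gives 3700 nM, which places it second highest of the three numbers. Compound 3 `C=C(CC)C(=O)c1ccc(OCC(=O)Nc2ccc(/C=C/C(=O)OCC)cc2)c(Cl)c1Cl` gives 1700 nM, and compound 2 `C=C(CC)C(=O)c1ccc(OCC(=O)NC2CCN(CC(=O)OC)CC2)c(Cl)c1Cl` gives 10600 nM. Going by the values given here, the only single-point step, a 2.2-fold lower number from compound 1 to compound 3 (0.34 log units; beyond the scatter), is a modest gain that comes from a change on the aromatic ring, not on the amide nitrogen.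

Compound 4 `C=C(CC)C(=O)c1ccc(OCC(=O)NC(CS)C(=O)OCC)c(Cl)c1Cl` is compound 1 with the change (1-(ethoxycarbonyl)-2-sulfanylethyl in place of 4-carbamoylphenyl on an amide-type nitrogen). Among the compounds with values here, no measured step touches the amide nitrogen directly, so the step has no close precedent. The nearest hint is compound 2, whose amide nitrogen also carries a non-aromatic group bearing an ester and whose number is the highest of the three. On that basis compound 4 is expected to need more compound than compound 1, an estimated step of a 1.9-fold higher number from compound 1 to compound 4 (0.28 log units; within the scatter), although this rests on one comparison only. The estimate for compound 4 is 7000 nM, with a range from 2500 nM to 20000 nM.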

Compound 4, half-maximal effective concentration: 4800 nM
Estimate against measurement, compound 4: 1.5-fold (0.16 log units) above, and the stated range covers the measured number.
By their numbers in this assay, from the lowest: compound 3; then compounds 1 and 4 (each within the scatter of the next); then compound 2.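

Going by these compounds alone, this is the first measured step at the amide-type nitrogen itself: in this assay, a 1.3-fold higher number from compound 1 to compound 4 (0.11 log units; within the scatter) stays within the scatter, so the two compounds cannot be told apart. The 4-carbamoylphenyl group, with its six-membered aromatic ring, can therefore give way on that nitrogen to the 1-(ethoxycarbonyl)-2-sulfanylethyl group, which has no ring, with no change beyond the scatter. Nothing available here explains this outcome.

The compounds shown leave open whether the sulfanyl group or the ethyl ester contributes to the number; a hydroxyl in place of the sulfanyl group, or a carboxylic acid in place of the ester, would test each part separately. A longer chain between the amide-type nitrogen and the ester also remains an open question.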